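Relocating the nitro group in compound 1

The source may report more compounds than this note shows. Statements on the series, on what has been measured and on what is new or still open speak of the compounds shown alone.

Of the compounds shown here, three sharing one core have been tested in a functional assay on MOLT-4 cells (Homo sapiens) for cytotoxicity, with a stated time of 72 h; on this read-out higher numbers stand for weaker inhibition and lower numbers for stronger inhibition. Compound 1 `COc1cc(/C=C2\CCC/C(=C\c3ccccc3[N+](=O)[O-])C2=O)cc(OC)c1OC` gives 702 nM. Compound 2 `O=C1CCCC/C1=C\c1ccccc1[N+](=O)[O-]` gives 33300 nM, and compound 3 `CN(C)c1ccc(/C=C2\CCC/C(=C\c3ccccc3[N+](=O)[O-])C2=O)cc1` gives 122000 nM. Compound 1 thus shows the lowest number of the three, and its gaps to compound 2 and compound 3 both lie beyond the usual scatter, so it is the strongest of these three.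

Compound 4 `COc1cc(/C=C2\CCC/C(=C\c3ccc([N+](=O)[O-])cc3)C2=O)cc(OC)c1OC` has not yet been measured in this assay. It differs from compound 1 in one place: 4-nitrophenyl in place of 2-nitrophenyl on a double-bonded chain carbon bound to a double-bonded ring carbon. The same atoms are present, joined differently. Among the compounds with values here, no two measured compounds differ in one place, so nothing observed here shows how such a change moves the number. As far as these compounds go, because compound 1 gives 702 nM and the effect of this change is unknown, the step of a 2.1-fold higher number from compound 1 to compound 4 (0.33 log units; beyond the scatter) is expected to be modest, with a wide range in either direction. For compound 4 the estimate in this assay is 1500 nM, between 300 nM and 8000 nM.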

Compound 4, half-maximal inhibitory concentration: 6420 nM
The estimate for compound 4 lay 4.3-fold (0.63 log units) below the measured number; measured number inside the range.
By their numbers in this assay, from the lowest: compound 1; then compound 4; then compound 2; then compound 3.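

In this assay, exchanging 2-nitrophenyl for 4-nitrophenyl gives a 9.1-fold higher number from compound 1 to compound 4 (0.96 log units; beyond the scatter), a step beyond the usual scatter. Within the data shown here, this is the first pair of measured compounds that differ in one place, and it shows that the number at this position responds to where the nitro group sits on the ring, even though the atoms stay the same. Of these two arrangements, the 2-nitrophenyl of compound 1 gives the stronger inhibition, but nothing available here explains why.

Whether the nitro group itself matters remains open, since no compound shown carries an amine or a nitrile on this ring in its place. Also open, as far as these compounds go, is whether the same exchange would move the number similarly in compound 2 or compound 3, which have no 4-nitrophenyl partners here.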